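The source may report more compounds than this note shows. Statements on the series, on what has been measured and on what is new or still open speak of the compounds shown alone.

Measured in a functional assay (aorta) with Rattus norvegicus as the target; on this read-out higher numbers stand for an effect only at larger amounts of compound and lower numbers for an effect already at smaller amounts:
Compound 1 `CN(C)/C(=N\C#N)C1=CC(C)(C)Oc2ccc(S(C)(=O)=O)cc21`: > 31600 nM (a limit)
Compound 2 `CN(C)/C(=N\C#N)C1=CC(C)(C)Oc2ccc(Br)cc21`: > 31600 nM (a limit)

Compound 1 stands only at a limit of this assay, so no actual number is known for it. For the measured compounds named here, the same holds for the only other measured compound, as the limit of > 31600 nM in this assay, at which 2 of the 2 values shown sit, shows.

Compound 3 `CN(C)/C(=N\C#N)C1=CC(C)(C)Oc2ccccc21` carries hydrogen in place of methylsulfonyl on an aromatic carbon.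

Going by the values given here, one measured step bears on this change, also a replacement of methylsulfonyl on an aromatic carbon, this time by bromo: a step that the two limits leave unreadable from compound 1 to compound 2. It offers no size to carry over, and neither compound gives a number. A clear gain in potency is therefore not expected, and compound 3 will most likely be reported as a limit too. The expected change is a step that the limit leaves unreadable from compound 1 to compound 3. Compound 3 is estimated at 35000 nM, with an expected range from 10000 nM to 100000 nM.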

Compound 3, half-maximal effective concentration: > 31600 nM
Compound 3 was reported as a limit; the forecaster's own chance of this, stated with the estimate: 80%; the middle value does not contradict the limit.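

No step among compound 1, compound 2 and compound 3 can be read, since all three are reported only as a limit and not as a number: the limit of > 31600 nM in this assay, at which 3 of the 3 values shown sit.

Left open is whether methylsulfonyl, bromo or hydrogen on the aromatic carbon makes any difference in this assay, and at what amount any of these compounds would show an effect.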